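The source may report more compounds than this note shows. Statements on the series, on what has been measured and on what is new or still open speak of the compounds shown alone.

Compound 1 `CCn1c(C(=O)N[C@@H](C)CO)ccc1C(CC)(CC)c1ccc(OCS(=O)(=O)c2ccccc2)c(C)c1`, compound 2 `CCn1c(C(=O)NCCO)ccc1C(CC)(CC)c1ccc(OCS(=O)(=O)c2ccccc2)c(C)c1` and compound 3 `CCn1c(C(=O)NCC(=O)O)ccc1C(CC)(CC)c1ccc(OCS(=O)(=O)c2ccccc2)c(C)c1` share a core and differ only in the group on the amide nitrogen. In a functional assay on PC-3 cells (Homo sapiens) for antiproliferative activity, read by MTT assay, with a stated time of 24 h (on this read-out higher numbers stand for weaker inhibition and lower numbers for stronger inhibition), compound 1 gives 9520 nM, compound 2 gives 17700 nM and compound 3 gives 30100 nM. The change from compound 2 to compound 1, (methyl in place of hydrogen on a saturated chain carbon bound to an amide-type nitrogen and a saturated chain carbon), brings a 1.9-fold lower number from compound 2 to compound 1 (0.27 log units; within the scatter). The cores of compound 2 and compound 3 differ by carboxy in place of hydroxymethyl on a saturated chain carbon bound to an amide-type nitrogen, which gives a 1.7-fold higher number from compound 2 to compound 3 (0.23 log units; within the scatter), while a 3.2-fold higher number from compound 1 to compound 3 (0.50 log units; beyond the scatter).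

Compound 4 `CCn1c(C(=O)N[C@H](C)C(=O)O)ccc1C(CC)(CC)c1ccc(OCS(=O)(=O)c2ccccc2)c(C)c1` is not yet measured. It differs from compound 3 by methyl in place of hydrogen on a saturated chain carbon bound to an amide-type nitrogen and a carbonyl carbon. This is the same kind of change as that from compound 2 to compound 1, but not the same: in compound 4 the carbon also bears a carbonyl carbon, where in compound 1 it bears a saturated chain carbon. For compound 4 the step from compound 3 is expected to be a 1.6-fold lower number from compound 3 to compound 4 (0.20 log units; within the scatter), resting on the step of a 1.9-fold lower number from compound 2 to compound 1 (0.27 log units; within the scatter) seen on the neighbouring core. Compound 4 is therefore estimated at 19000 nM, between 8000 nM and 45000 nM.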

Compound 4, half-maximal inhibitory concentration: 20100 nM
Estimate against measurement, compound 4: 1.1-fold (0.02 log units) below, and the stated range covers the measured number.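

In this assay, methyl in place of hydrogen gives a 1.5-fold lower number from compound 3 to compound 4 (0.18 log units; within the scatter), and the two steps for this change agree: the same change on two cores in this assay, a 1.9-fold lower number (0.27 log units; within the scatter) from compound 2 to compound 1 and a 1.5-fold lower number (0.18 log units; within the scatter) from compound 3 to compound 4, 1.2-fold (0.09 log units) apart, within the scatter of two such steps

This shows that the change behaves alike on the two cores shown, with neither step going beyond the scatter, but it does not show that the methyl has a real effect of its own on either core, and two cores in one assay set no rule for the series. With 1-carboxyethyl on the amide nitrogen, the comparisons with the hydroxyl-bearing groups read a 1.1-fold higher number from compound 2 to compound 4 (0.06 log units; within the scatter) and a 2.1-fold higher number from compound 1 to compound 4 (0.32 log units; beyond the scatter), so only the second of these exceeds the scatter, and modestly.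

The compounds shown leave open whether a larger group on this saturated chain carbon, such as ethyl or benzyl, would give a step beyond the scatter. They also leave open how a methyl ester or a primary amide in place of the carboxylic acid would read.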